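The source may hold more compounds than are shown below. What is called first, only, known or untested is meant among the compounds shown, and "the series" means these compounds.

Working notes on the series. Compound 1 `O=C(CCC(=O)OCCCCCCSc1ccc([N+](=O)[O-])c2nonc12)Nc1ccccc1F` gives 2350 nM in a functional assay on HOS cells (Homo sapiens) for inhibition, read by MTT assay, with a stated time of 72 h; on this read-out higher numbers stand for weaker inhibition and lower numbers for stronger inhibition. Compound 2 `O=C(CCC(=O)OCCCCCCSc1ccc([N+](=O)[O-])c2nonc12)Nc1ccc(F)cc1` gives 2080 nM in this assay, a step of a 1.1-fold lower number from compound 1 to compound 2 (0.05 log units; within the scatter). On the two numbers shown compound 2 sits nominally at the lowest, but that step is within the scatter, so no order between the two is established.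

Compound 3 `O=C(CCC(=O)N1CCOCC1)OCCCCCCSc1ccc([N+](=O)[O-])c2nonc12` is not yet measured. Its difference from compound 2 is morpholin-4-yl in place of (4-fluorophenyl)amino on a carbonyl carbon. For the measured compounds named here, no measured step bears on this change: the only step in hand, from compound 1 to compound 2, exchanges one fluorophenyl for another on the amide-type nitrogen and was within the scatter, whereas here the (4-fluorophenyl)amino group is replaced outright by morpholin-4-yl on the carbonyl carbon. The expectation is therefore a step of a 1.2-fold higher number from compound 2 to compound 3 (0.08 log units; within the scatter) with wide uncertainty and no preferred direction. Compound 3 is estimated at 2500 nM, range 700 nM to 9000 nM in this assay.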

Compound 3, half-maximal inhibitory concentration: 1010 nM
Estimate against measurement, compound 3: 2.5-fold (0.39 log units) above, within the range that was stated.
By their numbers in this assay, from the lowest: compound 3; then compounds 2 and 1 (each within the scatter of the next).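

For the compounds shown here, the carbonyl carbon is the first place where a change moves the number beyond the scatter in this assay: there is a 2.1-fold lower number from compound 2 to compound 3 (0.31 log units; beyond the scatter) and a 2.3-fold lower number from compound 1 to compound 3 (0.37 log units; beyond the scatter), both modest. Whereas exchanging one fluorophenyl for another left the number within the scatter, replacing the whole arylamino group with morpholin-4-yl shows that neither the aromatic ring nor the amide hydrogen is required for activity at this level. No measured information on these compounds accounts for the lower number.

Still open, from the compounds shown here alone, is whether the step depends on the morpholine ring oxygen or only on loss of the amide hydrogen, which piperidin-1-yl or dimethylamino on the same carbonyl carbon would help separate. Also open, going by these compounds, is whether the step holds with a shorter or longer chain to the shared core.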